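Methoxy added to a compound beyond the assay limit

The compounds below may be only part of what the source reports. "The series", "measured", "known", "first", "only" and "open" are said of these compounds alone.

- compound 1 `COc1cc(C#N)ccc1OCc1nnc(-c2ccccc2)o1` gives 32200 nM
- compound 2 `COc1ccc(-c2nnc(COc3ccc(C#N)cc3OC)o2)cc1` gives 11100 nM
- compound 3 `N#Cc1ccc(OCc2nnc(-c3ccccc3)o2)cc1F` gives > 50000 nM (a limit)

In a functional assay on MCF7 cells (Homo sapiens) for cytotoxicity, read by MTT assay, with a stated time of 48 h (on this read-out higher numbers stand for weaker inhibition and lower numbers for stronger inhibition), compound 3 gives only a limit (> 50000 nM) and no exact number. Compound 4 `COc1ccc(-c2nnc(COc3ccc(C#N)c(F)c3)o2)cc1` differs from compound 3 in one place (methoxy in place of hydrogen on an aromatic carbon) as phenyl becomes 4-methoxyphenyl. The same change has been measured once (a 2.9-fold lower number from compound 1 to compound 2 (0.46 log units; beyond the scatter)) so a modest move toward stronger inhibition is expected in this assay on the evidence of that single pair. The expected step (an at least 2.2-fold lower number from compound 3 to compound 4 (0.35 log units; beyond the scatter)) starts from a limit and is therefore uncertain. Compound 4 is estimated at 22000 nM with an expected range from 9000 nM to 50000 nM in this test.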

Compound 4, half-maximal inhibitory concentration: 42200 nM
Compound 4: the middle estimate sits 1.9-fold (0.28 log units) below what was measured; the range from low to high includes it.
By their numbers in this assay, from the lowest: compound 2; then compounds 1 and 4 (each within the scatter of the next). At a limit, above all of these: compound 3.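

In this assay the change from phenyl to 4-methoxyphenyl on a second core gives an at least 1.1-fold lower number from compound 3 to compound 4 (0.07 log units; that floor lies within the scatter) so the clearer gain seen on the first core is not confirmed here. From the compounds shown here alone, compound 3 stands at a limit, so the true size of this step is unknown and the two cores cannot be told apart: the same change on two cores in this assay, a 2.9-fold lower number (0.46 log units; beyond the scatter) from compound 1 to compound 2 and an at least 1.1-fold lower number (0.07 log units; that floor lies within the scatter) from compound 3 to compound 4; the limit leaves it open whether they differ. The compounds shown leave open what a different group at this place would do, such as an ethoxy group, an amine or a carboxylic acid.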